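This account rests on a few compounds, and the source may have more. Where it says the series, first, only, none or still open, it means among the compounds named here.

Series notes. Compound 1 `O=C(CCCCC[C@H](NC(=O)c1cc2ccccc2[nH]1)C(=O)NCc1ccccc1)NO` in a functional assay on NFF cells (Homo sapiens) for antiproliferative activity (on this read-out lower numbers stand for stronger inhibition and higher numbers for weaker inhibition), gives 1260 nM. Compound 2 `CN(C)c1ccc(C(=O)N[C@@H](CCCCCC(=O)NO)C(=O)NC2(Cc3ccccc3)CCCC2)cc1` in this assay gives 3000 nM, the higher of the two numbers, and its gap to compound 1 lies beyond the scatter. Compound 3 `O=C(CCCCC[C@H](NC(=O)c1cc2ccccc2[nH]1)C(=O)NC1(Cc2ccccc2)CCCC1)NO` is not yet measured; it carries 1H-indol-2-yl in place of 4-(dimethylamino)phenyl on a carbonyl carbon. Among the compounds with values here, no single-change step between measured compounds is available, and compound 1 differs from compound 2 in more than one place, so the cap change stands on its own here. A moderate fall is expected in this assay, a 2.0-fold lower number from compound 2 to compound 3 (0.30 log units; within the scatter) being the step meant. Compound 3 is estimated at 1500 nM, range 600 nM to 4000 nM.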

Compound 3, half-maximal inhibitory concentration: 1600 nM
Compound 3: middle estimate off by 1.1-fold (0.03 log units), on the low side, within the range that was stated.
By their numbers in this assay, from the lowest: compounds 1, 3 and 2 (each within the scatter of the next, the first and the last beyond it).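

In this assay, 1H-indol-2-yl in place of 4-(dimethylamino)phenyl on a carbonyl carbon gives a step that stays within the scatter (a 1.9-fold lower number from compound 2 to compound 3 (0.27 log units; within the scatter)). The other single change, 1-benzylcyclopentyl in place of benzyl on an amide-type nitrogen, also stays within the scatter (a 1.3-fold higher number from compound 1 to compound 3 (0.10 log units; within the scatter)). Nothing available explains either step.

Still open, from the compounds shown here alone, is whether a simple phenyl or a pyridine ring on that carbonyl carbon would give a step beyond the scatter. The same question holds for a longer chain ending in phenyl on that nitrogen.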